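Methoxy for Trifluoromethyl on the Urea Aryl Ring

The compounds below may be only part of what the source reports. "The series", "measured", "known", "first", "only" and "open" are said of these compounds alone.

Of the compounds shown here, three sharing one core have been measured in a functional assay on Shh Light II cells (Mus musculus) for inhibition, read by a luciferase reporter; a higher number here means a weaker inhibitor, a lower number a stronger inhibitor. Compound 1 `O=C(Nc1ccccc1Cl)N1CCN(c2nc(-c3ccc4ccccc4n3)no2)CC1` gives 140 nM in this assay. Compound 2 `C[C@@H]1C[C@H](c2nc(-c3ccc4ccccc4n3)no2)CCN1C(=O)Nc1ccccc1Cl` gives 2400 nM. Compound 3 `O=C(Nc1ccccc1C(F)(F)F)N1CCC(c2nc(-c3ccc4ccccc4n3)no2)CC1` gives 700 nM, which places it second highest of the three numbers: its nearest neighbour is compound 2, whose higher number lies beyond the scatter, and its furthest is compound 1, whose lower number also lies beyond the scatter. Compound 3 therefore sits between the other two, closer to compound 2 than to compound 1.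

Compound 4 `COc1ccccc1NC(=O)N1CCC(c2nc(-c3ccc4ccccc4n3)no2)CC1` keeps the core and the piperidine of compound 3 and alters only the aryl group of the urea: methoxy in place of trifluoromethyl on an aromatic carbon. Put one bond further out, 2-(trifluoromethyl)phenyl becomes 2-methoxyphenyl. For the measured compounds named here, no measured pair shows this particular exchange, so there is no step to lean on, and the expectation rests on the spread among compounds 1, 2 and 3 in this assay.

Compound 4 is expected to give about 1000 nM in this assay, within a range of 300 nM to 3500 nM. The expected step of a 1.4-fold higher number from compound 3 to compound 4 (0.15 log units; within the scatter) is modest, toward a slightly higher number but not clearly beyond the scatter.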

Compound 4, half-maximal inhibitory concentration: 410 nM
Compound 4: middle estimate off by 2.4-fold (0.39 log units), on the high side, within the range that was stated.
By their numbers in this assay, from the lowest: compound 1; then compounds 4 and 3 (each within the scatter of the next); then compound 2.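

For the compounds shown here, the exchange of trifluoromethyl for methoxy on this aromatic carbon is the first change that can be read at a single place, and in this assay it gives a 1.7-fold lower number from compound 3 to compound 4 (0.23 log units; within the scatter), so the two compounds cannot be told apart. The aryl group of the urea thus accepts a group of 2 heavy atoms with 1 hydrogen-bond acceptor in place of one of 4 heavy atoms with none, and the number stays within the scatter, which is as far as this single pair reaches. Nothing measured alongside these values speaks to why the two groups read alike.

This single exchange leaves open whether a much different group on the same aromatic carbon, such as an amine, a carboxylic acid or a nitrile, would also stay within the scatter of compound 3, and what a bare phenyl ring would give. It also leaves open whether methoxy and trifluoromethyl would read alike on the core of compound 1, since a single pair on the piperidine cannot show how far the result carries to other cores.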